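A few compounds are considered here, and "the series" means these few. Any claim that something is new, unique, unknown or untested is made for them only; others in the source may bear on it.

Measured so far:
- compound 1 `C/C=C1/[C@H](O[C@@H]2O[C@H](COC(C)=O)[C@@H](OC(C)=O)[C@H](OC(C)=O)[C@H]2OC(C)=O)OC=C(C(=O)OC)[C@H]1CC(=O)SCCC` gives > 15000 nM in a functional assay on SK-BR-3 cells (Homo sapiens) for antiproliferative activity, read by MTT assay, with a stated time of 72 h; on this read-out lower numbers stand for stronger inhibition and higher numbers for weaker inhibition; this is a limit of the assay, not a number.
- compound 2 `C/C=C1/[C@H](O[C@@H]2O[C@H](CO)[C@@H](O)[C@H](O)[C@H]2O)OC=C(C(=O)OC)[C@H]1CC(=O)O` gives > 15000 nM in this assay; again only a limit.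
- compound 3 `C/C=C1/[C@H](O[C@@H]2O[C@H](CO)[C@@H](O)[C@H](O)[C@H]2O)OC=C(C(=O)OC)[C@H]1CC(=O)OCCc1ccccc1` gives 11000 nM in this assay.

Compound 1 therefore stands at the limit of the assay, the position shared by the limit of > 15000 nM in this assay, at which 2 of the 3 values shown sit; no finished number exists for it, so it cannot be ranked against compound 3, and nothing separates it from compound 2.

The next compound, compound 4 `C/C=C1/[C@H](O[C@@H]2O[C@H](COC(C)=O)[C@@H](OC(C)=O)[C@H](OC(C)=O)[C@H]2OC(C)=O)OC=C(C(=O)OC)[C@H]1CC(=O)OCCCC`, keeps the peracetylated sugar of compound 1 and changes only the acyl terminus: butoxy in place of propylsulfanyl on a carbonyl carbon.

Among the compounds with values here, only one measured step is available, an at least 1.3-fold lower number from compound 2 to compound 3 (0.13 log units; that floor lies within the scatter), and it concerns the free-sugar pair, where an ester replaces an acid; its size lies inside the scatter. Within the data shown here, no measured pair compares a (propylsulfanyl)carbonyl group with a butoxycarbonyl group, and no pair varies the terminus on the peracetylated core. The step from compound 1 to compound 4 is thus unsupported by direct precedent, and the limit for compound 1 leaves its starting point open.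

Compound 4 is expected to stay in the same region, with the step of a number no higher from compound 1 to compound 4 (the limit leaves the size open) taken as no change beyond the scatter. The estimate for compound 4 is 15000 nM, with a range from 7000 nM to 40000 nM, and a limit read-out is the more likely outcome.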

Compound 4, half-maximal inhibitory concentration: > 15000 nM
Compound 4: no number, only a limit (the forecaster's own chance of this, stated with the estimate: 60%); the middle value lies on the limit itself.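

Compound 4, like compound 1, returns only a limit and not a number in this assay, so no step can be read from compound 1 to compound 4. The compounds shown leave open whether butoxy in place of propylsulfanyl on a carbonyl carbon alters the read-out on the core of compound 1, since the results gather at one point: the limit of > 15000 nM in this assay, at which 3 of the 4 values shown sit.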